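Replacing cyano on the amide-type nitrogen of compound 3

This account rests on a few compounds, and the source may have more. Where it says the series, first, only, none or still open, it means among the compounds named here.

In a functional assay on MOLM-13 cells (Homo sapiens) for antiproliferative activity (a lower number here means a stronger inhibitor, a higher number a weaker inhibitor), compound 2 `Cc1c(-c2ccc(-c3ccccc3F)cc2)nc2ccc(F)cc2c1C(N)=O`, with amino on the carbonyl carbon, gives 128 nM. Compound 1 `Cc1c(-c2ccc(-c3ccccc3F)cc2)nc2ccc(F)cc2c1C(=O)C(F)(F)F`, with trifluoromethyl there, gives > 3000 nM, which is a limit of the assay. Compound 3 `Cc1c(-c2ccc(-c3ccccc3F)cc2)nc2ccc(F)cc2c1C(=O)NC#N` gives > 3000 nM, which is also a limit, so no number fixes where it stands. That is the limit of > 3000 nM in this assay, at which 2 of the 3 values shown sit.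

Compound 4 `Cc1c(-c2ccc(-c3ccccc3F)cc2)nc2ccc(F)cc2c1C(=O)NS(C)(=O)=O` has methylsulfonyl in place of cyano on an amide-type nitrogen. The closest measured change is an at least 23-fold higher number from compound 2 to compound 3 (1.36 log units; beyond the scatter), where cyano replaced hydrogen on that nitrogen. Also relevant is an at least 23-fold lower number from compound 1 to compound 2 (1.36 log units; beyond the scatter). Compound 4 likewise lacks the hydrogen kept by compound 2, so no recovery is expected. The estimated change is a number no higher from compound 3 to compound 4 (the limit leaves the size open), with none expected beyond the scatter. Compound 4 is expected at 3000 nM, within an estimated range of 1000 nM to 9000 nM.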

Compound 4, half-maximal inhibitory concentration: 300 nM
For compound 4 the middle estimate is 10-fold (1.00 log units) above the measured one; the whole stated range lies above it.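

In this assay, a group on the amide-type nitrogen in place of hydrogen does not always bring the loss seen with cyano, as shown by an at least 10-fold lower number from compound 3 to compound 4 (1.00 log units; beyond the scatter). Methylsulfonyl on that nitrogen still carries a cost against hydrogen, with a 2.3-fold higher number from compound 2 to compound 4 (0.37 log units; beyond the scatter), yet it stands well clear of trifluoromethyl on the carbonyl carbon, with an at least 10-fold lower number from compound 1 to compound 4 (1.00 log units; beyond the scatter). Compound 1 and compound 3 each stand at a limit, so the full size of their steps is not fixed: the limit of > 3000 nM in this assay, at which 2 of the 4 values shown sit.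

As far as these compounds go, whether acetyl or phenylsulfonyl on that nitrogen would match methylsulfonyl stays open. So does what a carboxylic acid would give in place of the carboxamide.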